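Swapping Acetyl for Benzoyl on the Chloro Analogue

A few compounds are considered here, and "the series" means these few. Any claim that something is new, unique, unknown or untested is made for them only; others in the source may bear on it.

Compound 1, `CC(=O)N(/N=N/c1ccc([N+](=O)[O-])cc1Br)c1ccc([N+](=O)[O-])cc1Br`: 550 nM
Compound 2, `O=C(c1ccccc1)N(/N=N/c1ccc([N+](=O)[O-])cc1Br)c1ccc([N+](=O)[O-])cc1Br`: 1530 nM
Compound 3, `CC(=O)N(/N=N/c1ccc([N+](=O)[O-])cc1Cl)c1ccc([N+](=O)[O-])cc1Cl`: 630 nM

These three compounds were tested in a functional assay on HeLa cells (Homo sapiens) for cytotoxicity, read by MTT assay, with a stated time of 72 h; on this read-out higher numbers stand for weaker inhibition and lower numbers for stronger inhibition. Compound 2 differs from compound 1 by phenyl in place of methyl on a carbonyl carbon, and that change produced a 2.8-fold higher number from compound 1 to compound 2 (0.44 log units; beyond the scatter). Compound 3 carries the same acetyl group as compound 1; how its core differs from the core of compound 1 is not broken down here, and in this assay its number sits close to that of compound 1.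

Compound 4, `O=C(c1ccccc1)N(/N=N/c1ccc([N+](=O)[O-])cc1Cl)c1ccc([N+](=O)[O-])cc1Cl`, has not been measured. It differs from compound 3 by phenyl in place of methyl on a carbonyl carbon, the same change made between compound 1 and compound 2. Because a 2.8-fold higher number from compound 1 to compound 2 (0.44 log units; beyond the scatter) was seen, a step of similar size is expected here, namely a 2.7-fold higher number from compound 3 to compound 4 (0.43 log units; beyond the scatter). On that basis compound 4 is estimated at 1700 nM, most likely between 800 nM and 3600 nM.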

Compound 4, half-maximal inhibitory concentration: 590 nM
The estimate for compound 4 lay 2.9-fold (0.46 log units) above the measured number, outside the stated range (below it).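

In this assay, putting benzoyl in place of acetyl on the second core gives a 1.1-fold lower number from compound 3 to compound 4 (0.03 log units; within the scatter), so the loss of inhibition seen on the first core does not appear here. The size of this change therefore does not carry over from one core to the other: the same change on two cores in this assay, a 2.8-fold higher number (0.44 log units; beyond the scatter) from compound 1 to compound 2 and a 1.1-fold lower number (0.03 log units; within the scatter) from compound 3 to compound 4, 3.0-fold (0.47 log units) apart, beyond the scatter of two such steps. This shows that, for these two pairs, the result of the swap depends on the core, but it does not show which difference between the cores matters or how the swap would behave on any further core.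

As far as these compounds go, how a longer chain in place of methyl or phenyl on the carbonyl carbon would fare on either core remains open. So does the effect of an amine or a carboxylic acid on the phenyl group.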